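The compounds below may be only part of what the source reports. "The series", "measured", "known", "first", "only" and "open" are said of these compounds alone.

Three compounds share one core and differ only in the length of a saturated chain on an oxygen attached to an aromatic ring. Compound 1 `CCCCOc1ccc(-c2c(C)[nH]c(=O)n2C)cc1` gives 5100 nM in a functional assay on brain (Rattus norvegicus, strain Wistar) for inhibition; on this read-out higher numbers stand for weaker inhibition and lower numbers for stronger inhibition. Compound 2 `CCCCCCOc1ccc(-c2c(C)[nH]c(=O)n2C)cc1` gives 7300 nM, and compound 3 `CCCCCCCCOc1ccc(-c2c(C)[nH]c(=O)n2C)cc1` gives 4000 nM. The step of a 1.4-fold higher number from compound 1 to compound 2 (0.16 log units; within the scatter) and the step of a 1.8-fold lower number from compound 2 to compound 3 (0.26 log units; within the scatter) are both within the scatter, as is a 1.3-fold lower number from compound 1 to compound 3 (0.11 log units; within the scatter). Compound 3 therefore has the lowest of the three numbers, but its gaps to compound 1 and to compound 2 are both within the scatter, so nothing separates the three.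

Compound 4 `CCCCCCCCOc1ccc(-c2c(C)[nH]c(=O)n2C2CCCCC2)cc1` keeps the chain of compound 3 and changes a different place: cyclohexyl in place of methyl on an aromatic nitrogen. Among the compounds with values here, none of the measured steps touches the aromatic nitrogen; all three concern the chain on the oxygen, so no measured step bears on this change. Nothing here points in either direction, and the estimate for compound 4 is simply a number close to that of compound 3, with a wide range: 4000 nM, between 1000 nM and 16000 nM, meaning an expected step of no change at the digits printed from compound 3 to compound 4 (within the scatter).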

Compound 4, half-maximal inhibitory concentration: 8500 nM
For compound 4 the middle estimate is 2.1-fold (0.33 log units) below the measured one, within the range that was stated.
By their numbers in this assay, from the lowest: compounds 3, 1, 2 and 4 (each within the scatter of the next, the first and the last beyond it).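

Within the data shown here, the change on the aromatic nitrogen produces the first step in this set to lie beyond the scatter: in this assay, the replacement gives a 2.1-fold higher number from compound 3 to compound 4 (0.33 log units; beyond the scatter). The step is modest, so this position accepts cyclohexyl, a group of six carbons with a ring, in place of a single methyl carbon at only a small cost in inhibition, while the chain changes on the oxygen moved the number by no more than the scatter. Nothing available explains why this swap weakens inhibition.

Among these compounds, with only this one pair, the effect of the added size cannot be separated from that of the ring itself. Open too, from the compounds shown here alone, are whether an ethyl or a phenyl group on this nitrogen would fall closer to methyl or to cyclohexyl, and whether cyclohexyl would give a similar step on the shorter chain of compound 1.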